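This account rests on a few compounds, and the source may have more. Where it says the series, first, only, none or still open, it means among the compounds named here.

Of the compounds shown here, two built on the same core have been tested in a functional assay on HL-60 cells (Homo sapiens) for antiproliferative activity, with a stated time of 24 h; on this read-out higher numbers stand for weaker inhibition and lower numbers for stronger inhibition. Compound 1 `Cc1ccccc1CN1CCc2c(sc(NC(=O)c3ccccc3Cl)c2C(N)=O)C1` carries a 2-methylbenzyl group on the amine nitrogen of its saturated ring. In this assay compound 1 gives > 50000 nM, which is a limit of the assay rather than a number. Compound 2 `NC(=O)c1c(NC(=O)c2ccccc2F)sc2c1CCN(Cc1cccc(Cl)c1)C2` is the only one with a measured figure: in this assay compound 2 gives 19800 nM. Compound 1 therefore stands at the limit of > 50000 nM in this assay, at which 1 of the 2 values shown sits, with no number to say how far beyond it lies.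

Compound 3 `NC(=O)c1c(NC(=O)c2ccccc2Cl)sc2c1CCN(C(=O)Nc1ccccc1Cl)C2` is not yet measured. It differs from compound 1 in one place: (2-chlorophenyl)carbamoyl in place of 2-methylbenzyl on an amine nitrogen in a ring. Within the data shown here, no measured step joins two compounds of this set, so nothing calibrates the size of such a change. Because compound 1 sits at the limit of > 50000 nM in this assay, at which 1 of the 2 values shown sits, compound 3 is expected to stay weak, with a change of an at least 1.4-fold lower number from compound 1 to compound 3 (0.15 log units; that floor lies within the scatter) that need not exceed the scatter. The estimate for compound 3 in this assay is 35000 nM, between 8000 nM and 100000 nM.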

Compound 3, half-maximal inhibitory concentration: 12500 nM
Compound 3: the middle estimate sits 2.8-fold (0.45 log units) above what was measured; the measured number falls inside the stated range.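

On the amine nitrogen in the ring, the shared core does not need a 2-methylbenzyl group to show measurable activity: in this assay, (2-chlorophenyl)carbamoyl in its place gives an at least 4.0-fold lower number from compound 1 to compound 3 (0.60 log units; beyond the scatter). Among these compounds, this is the first step in the set that can be read, and it shows that the read-out responds to a change at this position. Its true size stays unknown, as compound 1 stands at a limit and not at a number: the limit of > 50000 nM in this assay, at which 1 of the 3 values shown sits.

The entering group differs in several ways at once, with a carbonyl, a hydrogen-bond donor and a chlorine, so this single step cannot say which of these parts matters, if any does. Also open, from the compounds shown here alone, is how an acetyl group or a longer alkyl chain on that nitrogen would read.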